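Cyclohexyl in place of 4-(trifluoromethyl)phenyl in compound 3

A few compounds are considered here, and "the series" means these few. Any claim that something is new, unique, unknown or untested is made for them only; others in the source may bear on it.

In a functional assay on OCI-Ly3 cells (Homo sapiens) for inhibition, read by CellTiter-Glo, with stated times of 48 h and 96 h (on this read-out lower numbers stand for stronger inhibition of growth and higher numbers for weaker inhibition of growth), compound 1 `CC(C)[C@H](NC(=O)c1ccc(Br)cc1)C(=O)N1CCC[C@H]1C(=O)N[C@@H](CCCNC(=N)N)C(=O)CF` gives 130 nM, and compound 2 `CC(C)[C@H](NC(=O)c1ccc(C(F)(F)F)cc1)C(=O)N1CCC[C@H]1C(=O)N[C@@H](CCCNC(=N)N)C(=O)CF` gives 120 nM. Within the data shown here, these are the only two numbers available, and they lie within the scatter of each other, so compound 2 stands level with compound 1. Among the measured compounds shown here, the one measured step, a 1.1-fold lower number from compound 1 to compound 2 (0.03 log units; within the scatter), puts trifluoromethyl in place of bromo on an aromatic carbon and stays within the scatter.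

Compound 3 `CC(C)[C@H](NC(=O)C1CCCCC1)C(=O)N1CCC[C@H]1C(=O)N[C@@H](CCCNC(=N)N)C(=O)CF` has not yet been measured. It differs from compound 2 by a larger change at the carbonyl carbon: cyclohexyl in place of 4-(trifluoromethyl)phenyl on a carbonyl carbon. For the measured compounds named here, the measured step keeps the aromatic ring, so it is only a weak guide here, and no measured compound carries a non-aromatic ring at this place. Going by the values given here, since the step of a 1.1-fold lower number from compound 1 to compound 2 (0.03 log units; within the scatter) is the only evidence, a small rise in the number is expected in this assay, towards weaker inhibition of growth, with real uncertainty in either direction. The estimated step is a 1.7-fold higher number from compound 2 to compound 3 (0.22 log units; within the scatter). For compound 3 the estimated value is 200 nM, with an expected range from 70 nM to 600 nM.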

Compound 3, concentration for 50% growth inhibition: 940 nM
For compound 3 the middle estimate is 4.7-fold (0.67 log units) below the measured one; measured number above the stated range.
By their numbers in this assay, from the lowest: compounds 2 and 1 (each within the scatter of the next); then compound 3.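

In this assay, among these compounds, the group on this carbonyl carbon proves to matter far more than the earlier compounds could show: with cyclohexyl in place of 4-(trifluoromethyl)phenyl the result is a 7.8-fold higher number from compound 2 to compound 3 (0.89 log units; beyond the scatter), and with cyclohexyl in place of 4-bromophenyl it is a 7.2-fold higher number from compound 1 to compound 3 (0.86 log units; beyond the scatter). Both steps lie beyond the scatter and both point towards weaker inhibition of growth, whereas trifluoromethyl in place of bromo on the aromatic ring gave only a 1.1-fold lower number from compound 1 to compound 2 (0.03 log units; within the scatter), which stays within the scatter. Among these three compounds, then, exchanging the substituent on the aromatic ring leaves the read-out level, while exchanging the whole ring for cyclohexyl does not, and nothing measured here accounts for that difference.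

The compounds shown leave open whether the weaker inhibition goes with losing the aromatic ring itself or with losing the substituent that both phenyl groups carry, a question that plain phenyl or 4-(trifluoromethyl)cyclohexyl at this place would address. They also leave open how a ring holding nitrogen, such as pyridine, or an open chain, such as a longer alkyl chain, would fare on this carbonyl carbon.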